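Replacing the Amide of Compound 3 with a Piperidine

A few compounds are considered here, and "the series" means these few. Any claim that something is new, unique, unknown or untested is made for them only; others in the source may bear on it.

Compound 1 `COC(=O)C=CC(=O)c1sc(Nc2cccc(C)c2)nc1-c1ccncc1`: 2510 nM
Compound 2 `Cc1cccc(Nc2nc(-c3ccncc3)c(C(N)=O)s2)c1`: 19500 nM
Compound 3 `Cc1cccc(Nc2nc(-c3ccncc3)c(C(=O)N(C)C)s2)c1`: 16200 nM

All three values come from a functional assay on RCC4 cells (Homo sapiens) for inhibition, read by XTT assay, with a stated time of 4 days (a higher number here means a weaker inhibitor, a lower number a stronger inhibitor), and compound 3 stands second highest among them. It lies close to one neighbour, with a 1.2-fold lower number from compound 2 to compound 3 (0.08 log units; within the scatter) as the step, and further from the other, with a 6.5-fold higher number from compound 1 to compound 3 (0.81 log units; beyond the scatter) as the step.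

The next compound is compound 4 `Cc1cccc(Nc2nc(-c3ccncc3)c(CN3CCCCC3)s2)c1` which has not yet been measured. The change is (piperidin-1-yl)methyl in place of dimethylcarbamoyl on an aromatic carbon and it puts (piperidin-1-yl)methyl in place of dimethylcarbamoyl on an aromatic carbon. For the measured compounds named here, no measured step makes this exchange. The closest guides are changes on a carbonyl carbon: a 1.2-fold lower number from compound 2 to compound 3 (0.08 log units; within the scatter) is within the scatter, while a 7.8-fold higher number from compound 1 to compound 2 (0.89 log units; beyond the scatter) and a 6.5-fold higher number from compound 1 to compound 3 (0.81 log units; beyond the scatter) are modest. Compound 4 has no carbonyl at this place, so these steps guide only loosely, and no direction can be drawn from them. The expected step is a 1.4-fold lower number from compound 3 to compound 4 (0.13 log units; within the scatter) and no change beyond the scatter is expected. In this assay compound 4 is estimated at 12000 nM (expected range 3000 nM to 40000 nM).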

Compound 4, half-maximal inhibitory concentration: 13200 nM
For compound 4 the middle estimate is 1.1-fold (0.04 log units) below the measured one, within the range that was stated.
By their numbers in this assay, from the lowest: compound 1; then compounds 4, 3 and 2 (each within the scatter of the next).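

Replacing the amide carbonyl on this aromatic carbon, next to the ring sulfur, with the (piperidin-1-yl)methyl group leaves the read-out in this assay essentially unchanged: there is a 1.2-fold lower number from compound 3 to compound 4 (0.09 log units; within the scatter) and a 1.5-fold lower number from compound 2 to compound 4 (0.17 log units; within the scatter) in the same series. At this position, therefore, compounds 2, 3 and 4 read alike with or without a carbonyl on the attached group and with or without the six-membered non-aromatic ring. Only the (2-(methoxycarbonyl)ethenyl)carbonyl group of compound 1 stands apart, with a 5.3-fold higher number from compound 1 to compound 4 (0.72 log units; beyond the scatter) as the step, and no data here account for this difference.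

As far as these compounds go, whether a morpholine or an open-chain dimethylaminomethyl group would read like the piperidine remains open. So does whether a simple methyl ketone, a carboxylic acid or the ethenyl ester chain without its ketone carbonyl would keep the stronger inhibition of compound 1.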